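The source may hold more compounds than are shown below. What is called first, only, known or untested is meant among the compounds shown, and "the series" means these compounds.

Compound 1 `CN(Cc1ccc2c(c1)OCCO2)c1cc(=O)c2cc(C(F)(F)F)cc([N+](=O)[O-])c2s1` carries a 2,3-dihydro-1,4-benzodioxin-6-yl group on a saturated chain carbon bound to a nitrogen on an aromatic ring. In an ADME assay on Vero cells (Chlorocebus sabaeus) for cytotoxicity, read by MTT assay, with a stated time of 48 h (a lower number here means a stronger inhibitor, a higher number a weaker inhibitor), compound 1 gives > 64 ug/mL, which is a limit of the measurement rather than a number. Compound 2 `O=c1cc(NCc2ccc3c(c2)OCCO3)sc2c([N+](=O)[O-])cc(C(F)(F)F)cc12` differs from compound 1 by hydrogen in place of methyl on a nitrogen on an aromatic ring. In this assay compound 2 gives > 64 ug/mL, again a limit. The step between them is a step that the two limits leave unreadable from compound 1 to compound 2. For the measured compounds named here, compound 3 `O=c1nc(NCC2CCCCC2)oc2c([N+](=O)[O-])cc(C(F)(F)F)cc12`, built on another core, gives 29.7 ug/mL in this assay, the one numerical value in the set. Compound 1 thus stands at the limit of > 64 ug/mL in this assay, at which 2 of the 3 values shown sit, with compound 2 beside it.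

Compound 4 `CN(Cc1ccccc1)c1cc(=O)c2cc(C(F)(F)F)cc([N+](=O)[O-])c2s1` is not yet measured; it differs from compound 1 by phenyl in place of 2,3-dihydro-1,4-benzodioxin-6-yl on a saturated chain carbon bound to a nitrogen on an aromatic ring. Going by the values given here, no measured step touches this change: the single step within the shared core is unreadable, and compound 3 is separated from compound 1 by more than one change. No step beyond the scatter is expected in this assay, in either direction. Compound 4 is expected to give about 64 ug/mL in this assay, between 30 ug/mL and 130 ug/mL. The expected step is a number no higher from compound 1 to compound 4 (the limit leaves the size open), which most likely leaves compound 4 at the limit.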

Compound 4, half-maximal inhibitory concentration: > 64 ug/mL
Compound 4 ended at the assay's limit; the forecaster's own chance of this, stated with the estimate: 60%; the middle value sits exactly at the limit.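

Compound 1 and compound 4 both stand at the limit of this assay, so the change from 2,3-dihydro-1,4-benzodioxin-6-yl to phenyl gives no readable step. The compounds shown leave open whether either change on the shared core alters the read-out at all, since none of its compounds has a numerical value: the limit of > 64 ug/mL in this assay, at which 3 of the 4 values shown sit.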